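Fluorostilbene series: fluoro for hydrogen, second occurrence

A few compounds are considered here, and "the series" means these few. Any claim that something is new, unique, unknown or untested is made for them only; others in the source may bear on it.

Compound 1 `Fc1cccc(/C=C/c2ccccc2F)c1` is measured in an assay on HepG2 cells for activation of nuclear factor erythroid 2-related factor 2 (Homo sapiens), read by a luciferase reporter, with a stated time of 5 h (on this read-out lower numbers stand for an effect already at smaller amounts and higher numbers for an effect only at larger amounts of compound), only as a limit, > 15000 nM, as shown by the limit of > 15000 nM in this assay, at which 1 of the 3 values shown sits. Compound 3 `Fc1cccc(/C=C/c2cc(F)ccc2F)c1` gives 300 nM in this assay; the step of an at least 50-fold lower number from compound 1 to compound 3 (1.69 log units; beyond the scatter) comes from fluoro in place of hydrogen on an aromatic carbon. Compound 2 `Fc1ccc(/C=C/c2ccccc2F)cc1` gives 3600 nM in this assay; the difference between the two cores of compound 1 and compound 2 is not broken down here. Compound 4 `Fc1ccc(/C=C/c2ccccc2F)c(F)c1` carries fluoro in place of hydrogen on an aromatic carbon, the same kind of change as from compound 1 to compound 3, but with the entering fluoro ortho to a group of 9 heavy atoms and meta to a fluoro group, where before it was meta to that group and para to a fluoro group. Given the step of an at least 50-fold lower number from compound 1 to compound 3 (1.69 log units; beyond the scatter), a smaller gain, a 5.1-fold lower number from compound 2 to compound 4 (0.71 log units; beyond the scatter), is expected in this assay because the earlier start was only a limit of > 15000 nM in this assay, at which 1 of the 3 values shown sits, and the place differs. Compound 4 is estimated at 700 nM, between 200 nM and 3000 nM.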

Compound 4, half-maximal effective concentration: 9600 nM
Estimate against measurement, compound 4: 14-fold (1.14 log units) below; the measured number lies above the stated range.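

In this assay, fluoro in place of hydrogen on an aromatic carbon does not carry over as one step from one core to the other: the same change on two cores in this assay, an at least 50-fold lower number (1.69 log units; beyond the scatter) from compound 1 to compound 3 and a 2.7-fold higher number (0.43 log units; beyond the scatter) from compound 2 to compound 4, at least 130-fold (2.12 log units) apart, beyond the scatter of two such steps

The new step is a 2.7-fold higher number from compound 2 to compound 4 (0.43 log units; beyond the scatter), with the entering fluoro ortho to a group of 9 heavy atoms and meta to a fluoro group. Compound 1 stands only as a limit, > 15000 nM, and the two steps do not show whether the core or the place of the fluoro sets the outcome.

The compounds shown leave open whether a methoxy group, an amine or a carboxylic acid in place of the entering fluoro would follow either step. On these data alone, whether a third core would match either step also stays open.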